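Notes on a pyrimidinone series: cyano for methyl

This account rests on a few compounds, and the source may have more. Where it says the series, first, only, none or still open, it means among the compounds named here.

Measured compounds:
- compound 1, `CC(C)n1c(=O)[nH]c2ncc(Br)nc21`: "not determined" (no result reported) in an ADME assay on microsomes from liver (Rattus norvegicus), read by LC-MS, with a stated time of 90 min; a lower number here means that the liver removes a smaller share, a higher number that the liver removes a larger share of the compound in one pass
- compound 2, `CCC(CC)n1c(=O)[nH]c2ncc(C)nc21`: 0.7

Compound 1, `CC(C)n1c(=O)[nH]c2ncc(Br)nc21`, was run in this assay but its entry is "not determined" (no result reported), so it contributes nothing to the numbers. Compound 2, `CCC(CC)n1c(=O)[nH]c2ncc(C)nc21`, in this assay gives 0.7, and that is the only figure in hand; it therefore stands alone, with no neighbour to rank it against. The shared core is kept throughout.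

Compound 3, `CCC(CC)n1c(=O)[nH]c2ncc(C#N)nc21`, is the compound still to be measured. Relative to compound 2 it carries cyano in place of methyl on an aromatic carbon. No step between two measured compounds is shown for this assay, so the size of the move cannot be read from the series. The change is small in atom count, and the expectation is a modest shift of compound 2 toward compound 3 in this assay, downward, of a size near the usual scatter rather than far beyond it: the step from compound 2 to compound 3 is estimated as a number 0.15 lower from compound 2 to compound 3 (beyond the scatter). For compound 3 the estimated value in this assay is 0.55, with a range from 0.3 to 0.8.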

Compound 3, hepatic extraction ratio: < 0.2
Compound 3 ended at the assay's limit (the forecaster's own chance of this, stated with the estimate: 5%); middle value at least 0.35 away from the limit.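

Among these compounds, the aromatic carbon next to the ring nitrogen proves to be a highly sensitive position in this assay, where cyano in place of methyl gives a number at least 0.50 lower from compound 2 to compound 3 (beyond the scatter) in the only readable comparison so far. Compound 3 gives < 0.2, which is a limit of the assay and not a number: the limit of < 0.2 in this assay, at which 1 of the 3 values shown sits. Among the compounds shown here, until now the series held a single figure and no step, so nothing showed whether a change at this position could move the hepatic extraction ratio at all; this pair shows that it can, and by a large margin.

Going by these compounds, whether an amine, a methoxy group or a carboxamide at this position would read closer to compound 2 or to compound 3 stays open, as does whether the step carries over to the other substituent on the core of compound 1. The pair offers no measured property that accounts for the step, and the full distance between these two compounds cannot be read from a limit.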